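A few compounds are considered here, and "the series" means these few. Any claim that something is new, unique, unknown or untested is made for them only; others in the source may bear on it.

Measured compounds: compound 1, `CCCCOc1ccc(CN(O)C(C)=O)cc1`, gave 1100 nM; compound 2, `CCCCOc1ccc(C(CC)N(O)C(C)=O)cc1`, gave 740 nM; compound 3, `CCCCOc1ccc(C(C(C)C)N(O)C(C)=O)cc1`, gave 880 nM.

All three were tested in an assay on RBL-1 cells for inhibition of Polyunsaturated fatty acid 5-lipoxygenase (Rattus norvegicus); on this read-out lower numbers stand for stronger inhibition and higher numbers for weaker inhibition. Compound 3 sits at the second highest of the three numbers, with compound 2 nearest and compound 1 furthest, both within the scatter of it. The unmeasured compound 4, `CCCCOc1ccc(C(CCCC)N(O)C(C)=O)cc1`, differs from compound 3 as follows: butyl in place of isopropyl on a saturated chain carbon bound to an amide-type nitrogen and an aromatic carbon.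

Going by the values given here, the steps that bear on this change are those that alter the same saturated chain carbon bound to an amide-type nitrogen and an aromatic carbon: a 1.5-fold lower number from compound 1 to compound 2 (0.17 log units; within the scatter) and a 1.3-fold lower number from compound 1 to compound 3 (0.10 log units; within the scatter). The step of a 1.2-fold higher number from compound 2 to compound 3 (0.08 log units; within the scatter), which lengthens the same substituent by one carbon, also sits within the scatter. Every substituent tried at this place has left the number essentially where hydrogen put it, so a butyl group is expected to behave similarly, giving no step beyond the scatter in this assay, perhaps a slightly lower number if anything.

Compound 4 is therefore estimated at 750 nM, within a range of 330 nM to 1700 nM, which corresponds to an expected step of a 1.2-fold lower number from compound 3 to compound 4 (0.07 log units; within the scatter).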

Compound 4, half-maximal inhibitory concentration: 570 nM
Estimate against measurement, compound 4: 1.3-fold (0.12 log units) above; measured number inside the range.
By their numbers in this assay, from the lowest: compounds 4, 2, 3 and 1 (each within the scatter of the next).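

In this assay, butyl on the saturated chain carbon bound to an amide-type nitrogen and an aromatic carbon gives a 1.9-fold lower number from compound 1 to compound 4 (0.29 log units; within the scatter) when it replaces hydrogen, so even this four-carbon chain leaves the number inside the scatter of the unsubstituted compound. Set against the other substituents at this place, it gives a 1.5-fold lower number from compound 3 to compound 4 (0.19 log units; within the scatter) in place of isopropyl and a 1.3-fold lower number from compound 2 to compound 4 (0.11 log units; within the scatter) in place of ethyl, which means that none of the four compounds can be separated from another by this read-out, and hydrogen, ethyl, isopropyl and butyl are all tolerated to the same degree within the scatter. No measurement of any other kind bears on this result, so the numbers give no explanation for it.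

As far as these compounds go, it stays open whether a chain longer than butyl, such as hexyl or octyl, would carry the number beyond the scatter at this place. A carboxylic acid or an amine on the same carbon also remains untested in these compounds, so the flat picture holds only for the plain hydrocarbon chains shown here.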